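Cyano for Nitro in a Series at the Assay Limit

The source may report more compounds than this note shows. Statements on the series, on what has been measured and on what is new or still open speak of the compounds shown alone.

The two measured compounds in a functional assay on SK-OV-3 cells (Homo sapiens) for inhibition, read by MTT assay, with a stated time of 24 h (on this read-out higher numbers stand for weaker inhibition and lower numbers for stronger inhibition), are:
Compound 1, `CCOC(=O)c1c(C)[nH]c(=O)c(C#N)c1-c1ccc(C)cc1`, gives > 100000 nM, which is a limit of the assay.
Compound 2, `CCOC(=O)c1c(C)[nH]c(=O)c(C#N)c1-c1ccc([N+](=O)[O-])cc1`, gives > 100000 nM, again a limit and not a number.

Compound 2 therefore stands at the limit of this assay, and so does compound 1, as both values sit at the limit of > 100000 nM in this assay, at which 2 of the 2 values shown sit. Among the compounds with values here, the only measured step, a step that the two limits leave unreadable from compound 1 to compound 2, cannot be read in size for that reason.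

Compound 3, `CCOC(=O)c1c(C)[nH]c(=O)c(C#N)c1-c1ccc(C#N)cc1`, differs from compound 2 in one place: cyano in place of nitro on an aromatic carbon. No measured step bears on this change in a readable way, since the one step shown is hidden by the limit. The expectation for compound 3 is accordingly that this assay again reports a limit rather than a number, with an estimated step that the limit leaves unreadable from compound 2 to compound 3, none beyond the scatter. Compound 3 is estimated at 150000 nM, in the range 50000 nM to 500000 nM.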

Compound 3, half-maximal inhibitory concentration: > 100000 nM
Compound 3 was reported as a limit (the forecaster's own chance of this, stated with the estimate: 85%); the middle value does not contradict the limit.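

The steps among compound 1, compound 2 and compound 3 cannot be read in size, as all three stand at the limit: the limit of > 100000 nM in this assay, at which 3 of the 3 values shown sit. The compounds shown leave open whether any other group at this place would give a number rather than a limit in this assay.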